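A few compounds are considered here, and "the series" means these few. Any claim that something is new, unique, unknown or untested is made for them only; others in the source may bear on it.

Compound 1 `O=C(/C=C/c1ccc(OCc2cn(Cc3cccc(Br)c3)nn2)cc1)c1ccc(Br)cc1` and compound 2 `COc1ccc(C(=O)/C=C/c2ccc(OCc3cn(Cc4ccccc4)nn3)cc2)cc1` share the same core and differ in the groups at both ends. In a functional assay on HepG2 cells (Homo sapiens) for inhibition, read by MTT assay, with a stated time of 48 h, tested at 10 uM (on this read-out lower numbers stand for less inhibition of growth and higher numbers for more inhibition of growth at the one concentration tested), compound 1 gives 25% and compound 2 gives 51%, the higher of the two numbers by a margin beyond the usual scatter. Compound 3 `COc1ccc(C(=O)/C=C/c2ccc(OCc3cn(Cc4cccc(Br)c4)nn3)cc2)cc1` differs from compound 2 only by bromo in place of hydrogen on an aromatic carbon. Within the data shown here, no measured pair isolates this single change, so the expectation rests on compound 2 alone, with a small shift in this assay that is unlikely to go beyond the scatter. Compound 3 is estimated at 46%, with a range from 22% to 70%. The expected step is a number 5 percentage points lower from compound 2 to compound 3 (within the scatter).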

Compound 3, percent growth inhibition at one concentration: 27%
Beside the measured number, compound 3's estimate is 19 percentage points above it, within the range that was stated.
By their numbers in this assay, from the lowest: compounds 1 and 3 (each within the scatter of the next); then compound 2.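

In this assay, the change from benzyl to 3-bromobenzyl gives a number 24 percentage points lower from compound 2 to compound 3 (beyond the scatter), so this place on the ring is sensitive to bromo in place of hydrogen. With 3-bromobenzyl kept, methoxy in place of bromo at the other end gives a number 2 percentage points higher from compound 1 to compound 3 (within the scatter), so that exchange shows no clear effect here. Nothing available explains the drop seen with bromo.

On these data alone, whether a smaller chloro, a methyl or an amine at this place would give a similar step remains open. So does whether bromo elsewhere on this ring would match it.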